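Pyrazolidinedione series: aryl to styryl exchange at the exocyclic carbon

The source may report more compounds than this note shows. Statements on the series, on what has been measured and on what is new or still open speak of the compounds shown alone.

Measured so far:
compound 1, `CC(C)=C1C(=O)N(c2ccc(Cl)cc2)N(c2ccc(Cl)cc2)C1=O`, 39600 nM
compound 2, `CCC(C)=C1C(=O)N(c2ccc(Cl)cc2)N(c2ccc(Cl)cc2)C1=O`, 41600 nM
compound 3, `COc1cccc(C=C2C(=O)N(c3ccc(Cl)cc3)N(c3ccc(Cl)cc3)C2=O)c1O`, 26700 nM

All three share the same core and differ only in the substituent on the exocyclic double-bonded carbon. For the measured compounds named here, in a functional assay on MCF7 cells (Homo sapiens) for cytotoxicity, read by MTT assay, with a stated time of 72 h (on this read-out lower numbers stand for stronger inhibition and higher numbers for weaker inhibition), compound 1 gives 39600 nM and compound 2 gives 41600 nM; the only single-point step so far is a 1.1-fold higher number from compound 1 to compound 2 (0.02 log units; within the scatter). Compound 3 gives the lowest of the three numbers, but its gaps to compound 1 and compound 2 are both within the scatter, so no ordering among them can be claimed.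

Compound 4, `O=C1C(=C/C=C/c2ccccc2)C(=O)N(c2ccc(Cl)cc2)N1c1ccc(Cl)cc1`, is the next candidate. It differs from compound 3 by 2-phenylethenyl in place of 2-hydroxy-3-methoxyphenyl on a double-bonded chain carbon bound to a double-bonded ring carbon. Going by the values given here, the one measured step concerns a change on a saturated chain carbon and does not bear on this aryl-to-alkenyl exchange; no measured pair informs it. Among the compounds with values here, the series so far shows no movement beyond the scatter for any change at this position, so the expectation is a step of about a 1.0-fold higher number from compound 3 to compound 4 (0.00 log units; within the scatter), none beyond the scatter. Compound 4 is therefore estimated at 27000 nM, with a range from 8000 nM to 90000 nM.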

Compound 4, half-maximal inhibitory concentration: 9400 nM
Compound 4: middle estimate off by 2.9-fold (0.46 log units), on the high side; measured number inside the range.
By their numbers in this assay, from the lowest: compound 4; then compounds 3, 1 and 2 (each within the scatter of the next).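

The position on a double-bonded chain carbon bound to a double-bonded ring carbon does respond in this assay: 2-phenylethenyl in place of 2-hydroxy-3-methoxyphenyl gives the series its first step beyond the scatter (a 2.8-fold lower number from compound 3 to compound 4 (0.45 log units; beyond the scatter)), whereas the earlier step (a 1.1-fold higher number from compound 1 to compound 2 (0.02 log units; within the scatter)) stayed within it. The exchange removes the hydroxy and methoxy groups and adds a double bond outside aromatic rings in a single change, so the step cannot be assigned to either part alone. Nothing at hand gives a cause for the step.

On these data alone, whether the double bond or the loss of the hydroxy and methoxy groups carries the step remains open. Also open, as far as these compounds go, is how a plain phenyl, a 2-phenylethenyl bearing an amine or a carboxylic acid, or a longer unsaturated chain would read at this position.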